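Swapping Chloro for Trifluoromethoxy: An Expected Binding Number

This account rests on a few compounds, and the source may have more. Where it says the series, first, only, none or still open, it means among the compounds named here.

Of the compounds shown here, two sharing one core have been measured in an assay on cells with melanin-concentrating hormone receptor 1 (Homo sapiens) as the target, read by radioligand binding; on this read-out higher numbers stand for weaker inhibition and lower numbers for stronger inhibition. Compound 1 `N#Cc1cccc(C(=O)NCCCOc2cccc3ccc(N)nc23)c1` carries a cyano group, and in this assay compound 1 gives 3 nM. Compound 2 `Nc1ccc2cccc(OCCCNC(=O)c3cccc(Cl)c3)c2n1` has chloro in place of that cyano, and in this assay compound 2 gives 0.4 nM. The step of a 7.5-fold lower number from compound 1 to compound 2 (0.88 log units; beyond the scatter) is the only one measured, so compound 2 stands with the lowest of the two numbers, its nearest neighbour being compound 1 with a higher number beyond the scatter.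

Compound 3 `Nc1ccc2cccc(OCCCNC(=O)c3cccc(OC(F)(F)F)c3)c2n1` is not yet measured. It differs from compound 2 in one place: trifluoromethoxy in place of chloro on an aromatic carbon. Among the compounds with values here, no measured step involves a trifluoromethoxy group; the change from cyano to chloro, a 7.5-fold lower number from compound 1 to compound 2 (0.88 log units; beyond the scatter), shows only that this place tolerates a different group, not how the new one behaves. The expected step is therefore small, in either direction. Compound 3 is expected to give 0.8 nM, within a range from 0.2 nM to 4 nM. That estimate means a step of a 2.0-fold higher number from compound 2 to compound 3 (0.30 log units; within the scatter).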

Compound 3, half-maximal inhibitory concentration: 6 nM
The estimate for compound 3 lay 7.5-fold (0.88 log units) below the measured number; the whole stated range lies below it.
By their numbers in this assay, from the lowest: compound 2; then compounds 1 and 3 (each within the scatter of the next).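

At this position in this assay, replacing chloro is not always a small change: trifluoromethoxy, with five heavy atoms where chloro has one, gives a 15-fold higher number from compound 2 to compound 3 (1.18 log units; beyond the scatter) and so a large step. Trifluoromethoxy and cyano cannot be told apart here, as the comparison shows a 2.0-fold higher number from compound 1 to compound 3 (0.30 log units; within the scatter) and so stays within the scatter. Of the three groups, only chloro stands apart from both others by a step beyond the scatter, and nothing at hand says why the step from chloro to trifluoromethoxy is so large.

The compounds shown leave open whether another group of one heavy atom, such as fluoro or bromo, would keep a number as low as that of compound 2. Also open, on these data alone, is how trifluoromethyl, an amine or a carboxylic acid would behave at this place.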